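The source may report more compounds than this note shows. Statements on the series, on what has been measured and on what is new or still open speak of the compounds shown alone.

Of the compounds shown here, three with a shared core have been measured in a functional assay on NCI-H460 cells (Homo sapiens) for cytotoxicity, read by MTT assay, with a stated time of 72 h; a lower number here means a stronger inhibitor, a higher number a weaker inhibitor. Compound 1 `COc1ccc(-c2ccnc(C(=O)Nc3ccc(Oc4ccnc5cc(OCCCN6CCN(C)CC6)c(OC)cc45)c(F)c3)c2)cc1` carries a 4-methoxyphenyl group on its pyridine amide and gives 370 nM. Compound 2 `COc1cc2c(Oc3ccc(NC(=O)c4cc(-c5ccccc5C)ccn4)cc3F)ccnc2cc1OCCCN1CCCC1` has a different side chain on the core and a 2-methylphenyl group, and in this assay compound 2 gives 420 nM. Among the compounds with values here, compound 3 `COc1cc2c(Oc3ccc(NC(=O)c4cc(-c5ccccc5F)ccn4)cc3F)ccnc2cc1OCCCN1CCCC1` matches compound 2 except for the aryl group, and in this assay compound 3 gives 140 nM, the lowest of the three numbers; the one measured step, a 3.0-fold lower number from compound 2 to compound 3 (0.48 log units; beyond the scatter), is a fluoro in place of a methyl on an aromatic carbon.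

Compound 4 `COc1ccc(-c2ccnc(C(=O)Nc3ccc(Oc4ccnc5cc(OCCCN6CCCC6)c(OC)cc45)c(F)c3)c2)cc1` is the next member, not yet measured. It differs from compound 3 in one place: 4-methoxyphenyl in place of 2-fluorophenyl on an aromatic carbon. Within the data shown here, no measured step covers this exchange. The step from compound 2 to compound 3 concerns a different pair of groups and gives no direct guidance. What the numbers do show is that compound 4 shares its 4-methoxyphenyl group with compound 1, where it sits on a different side chain, and compound 1 gives 370 nM, while compound 3 gives 140 nM. On that basis a modest rise in this assay is expected, a 2.1-fold higher number from compound 3 to compound 4 (0.33 log units; beyond the scatter). Compound 4 is therefore expected to give about 300 nM, in a range from 120 nM to 750 nM.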

Compound 4, half-maximal inhibitory concentration: 200 nM
The estimate for compound 4 lay 1.5-fold (0.18 log units) above the measured number; measured number inside the range.
By their numbers in this assay, from the lowest: compounds 3, 4, 1 and 2 (each within the scatter of the next, the first and the last beyond it).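

At the aromatic carbon opposite the ring nitrogen, placing 4-methoxyphenyl where 2-fluorophenyl stood gives a 1.4-fold higher number from compound 3 to compound 4 (0.15 log units; within the scatter) in this assay, so these two aryl groups cannot be told apart in this assay. Placing 4-methoxyphenyl where 2-methylphenyl stood gives a 2.1-fold lower number from compound 2 to compound 4 (0.32 log units; beyond the scatter), and together with a 3.0-fold lower number from compound 2 to compound 3 (0.48 log units; beyond the scatter) this sets 2-methylphenyl apart from the other two aryl groups among the compounds carrying the pyrrolidin-1-yl chain. Within the data shown here, the result also gives the first comparison in which only the end of the side chain changes: with 4-methoxyphenyl held constant, pyrrolidin-1-yl in place of 4-methylpiperazin-1-yl gives a 1.9-fold lower number from compound 1 to compound 4 (0.27 log units; within the scatter), so this exchange on the chain does not separate the two compounds.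

Nothing available here accounts for these numbers. From the compounds shown here alone, it remains open what a 4-fluorophenyl, a 2-methoxyphenyl or an unsubstituted phenyl group would give at this aromatic carbon, which would separate the identity of the group from its place on the phenyl ring, and whether a morpholin-4-yl group at the end of the chain would fall in line with pyrrolidin-1-yl and 4-methylpiperazin-1-yl.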